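Working notes: from compound 2 to compound 3

The compounds below may be only part of what the source reports. "The series", "measured", "known", "first", "only" and "open" are said of these compounds alone.

- compound 1 `CNC(=O)c1cc(Oc2ccc(C(=O)/C=C/c3ccc(Cl)c(Cl)c3)cc2)ccn1` gives 8260 nM
- compound 2 `CNC(=O)c1cc(Oc2ccc(C(=O)/C=C/c3ccc(F)cc3)cc2)ccn1` gives 6140 nM

In a functional assay on PC-3 cells (Homo sapiens) for cytotoxicity, read by MTT assay, with a stated time of 72 h (on this read-out lower numbers stand for stronger inhibition and higher numbers for weaker inhibition), only these two compounds have been measured, and compound 2 stands level with compound 1 once the scatter is considered. Within the data shown here, the single measured step is a 1.3-fold lower number from compound 1 to compound 2 (0.13 log units; within the scatter). The next compound is compound 3 `CNC(=O)c1cc(Oc2ccc(C(=O)/C=C/c3cccc(Cl)c3Cl)cc2)ccn1`, which has 2,3-dichlorophenyl in place of 4-fluorophenyl on a double-bonded chain carbon bound to a double-bonded chain carbon.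

The measured step exchanges 4-fluorophenyl and 3,4-dichlorophenyl at the same place. It bears on this change, and a 1.3-fold lower number from compound 1 to compound 2 (0.13 log units; within the scatter) stays within the scatter. Among the measured compounds shown here, it is thin evidence, since it is one step, and no measured compound carries 2,3-dichlorophenyl. The range is therefore kept wide. No step beyond the scatter is expected in this assay, in either direction. The expected step is a 1.1-fold higher number from compound 2 to compound 3 (0.06 log units; within the scatter). For compound 3 the estimated value is 7000 nM, with an expected range of 3000 nM to 16000 nM.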

Compound 3, half-maximal inhibitory concentration: > 50000 nM
Compound 3 gave a limit, no number; the forecaster's own chance of this, stated with the estimate: 5%; at least 7.1-fold (0.85 log units) between middle value and limit.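

In this assay the entry for compound 3 is a limit of the assay and not a number: the limit of > 50000 nM in this assay, at which 1 of the 3 values shown sits.

Until now this place on the double-bonded chain carbon showed only an exchange within the scatter, a 1.3-fold lower number from compound 1 to compound 2 (0.13 log units; within the scatter), and it could have passed as indifferent to the aryl group it carries. The new steps end that reading: 2,3-dichlorophenyl gives an at least 8.1-fold higher number from compound 2 to compound 3 (0.91 log units; beyond the scatter), and also an at least 6.0-fold higher number from compound 1 to compound 3 (0.78 log units; beyond the scatter), both beyond the scatter. Compound 1 and compound 3 are both dichlorophenyl compounds and differ only in the numbers in the group's name, so the presence of chlorine does not decide the outcome at this place, and compound 1 goes against any reading that ties the weak result to dichlorophenyl as such.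

Open, going by these compounds, is whether 2-chlorophenyl or 3-chlorophenyl at this place would follow 2,3-dichlorophenyl or 3,4-dichlorophenyl, and whether a methoxy or dimethylamino group on the phenyl ring would be accepted here. On these data alone, the true size of both new steps also stays open, since they rest on a limit.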